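A few compounds are considered here, and "the series" means these few. Any claim that something is new, unique, unknown or untested is made for them only; others in the source may bear on it.

Compound 2, `COc1cc(Cl)cc(-c2nn(-c3cccc(NC(=O)Nc4ccc(Cl)c(Cl)c4)c3)cc2-c2ccncc2)c1`, stands highest of the two numbers measured in a functional assay on HCT-116 cells (Homo sapiens) for inhibition, read by sulforhodamine B assay, with a stated time of 48 h, tested at 10 uM (a lower number here means a stronger effect, a higher number a weaker effect of the compound at the concentration tested), where compound 2 gives 9.22%. Its nearest neighbour is compound 1, `COc1cc(Cl)cc(-c2nn(-c3cccc(NC(=O)Nc4ccc(Cl)c(C(F)(F)F)c4)c3)cc2-c2ccncc2)c1`, which in this assay gives 3.39%; the step of a number 5.8 percentage points higher from compound 1 to compound 2 (within the scatter) is the only one measured. Compound 3, `COc1cc(Cl)cc(-c2nn(-c3cccc(NC(=O)Nc4cccc(C(F)(F)F)c4)c3)cc2-c2ccncc2)c1`, differs from compound 2 at the urea end: 3-(trifluoromethyl)phenyl in place of 3,4-dichlorophenyl on an amide-type nitrogen. Among the compounds with values here, no measured step matches this change exactly; the single step from compound 1 to compound 2, which also swaps chloro and trifluoromethyl on that same ring, lay within the scatter, so the change from compound 2 to compound 3 is expected to move the number little, in either direction, and not beyond the scatter. Compound 3 is therefore estimated to give 9%, with a range of 1% to 30%. That estimate means an expected step of a number 0.2 percentage points lower from compound 2 to compound 3 (within the scatter), which is expected to stay within the scatter.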

Compound 3, a percentage reported as activity, at one concentration (the size of the read-out at that concentration, not a potency): 5.07%
Compound 3: the middle estimate sits 3.9 percentage points above what was measured; the range from low to high includes it.
By their numbers in this assay, from the lowest: compounds 1, 3 and 2 (each within the scatter of the next).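

In this assay, the step of a number 4.2 percentage points lower from compound 2 to compound 3 (within the scatter) shows that replacing 3,4-dichlorophenyl with 3-(trifluoromethyl)phenyl on the amide-type nitrogen changes two places on that ring at once and still leaves the number within the scatter. Within the data shown here, the step of a number 1.7 percentage points higher from compound 1 to compound 3 (within the scatter) adds the first reading of hydrogen in place of chloro on that ring. Compounds 1, 2 and 3 now form a closed set of single changes at the urea end, each within the scatter, and nothing available explains this tolerance.

As far as these compounds go, all three compounds carry a halogen-bearing aryl group there, so it remains open how an amine, a carboxylic acid or a longer alkyl chain on that ring would read. The read-out comes from a single concentration, so it shows only the size of the effect of the three compounds at that concentration and leaves open whether the effect would be stronger or weaker at any other.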